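A few compounds are considered here, and "the series" means these few. Any claim that something is new, unique, unknown or untested is made for them only; others in the source may bear on it.

Measured so far in a functional assay on PC-3 cells (Homo sapiens) for cytotoxicity, read by MTT assay, with a stated time of 48 h; a lower number here means a stronger inhibitor, a higher number a weaker inhibitor:
- compound 1, `CCNc1n[n+]([O-])c2ccccc2[n+]1[O-]`: 13300 nM
- compound 2, `[O-][n+]1nc(NC2CC2)[n+]([O-])c2ccccc21`: 15900 nM

Compound 2 gives the higher of the two numbers, but its gap to compound 1, the step of a 1.2-fold higher number from compound 1 to compound 2 (0.08 log units; within the scatter), lies within the scatter, so the two compounds cannot be told apart on these data. Compound 3, `CCN(CC)c1n[n+]([O-])c2ccccc2[n+]1[O-]`, has not yet been measured. It differs from compound 2 in one place: diethylamino in place of cyclopropylamino on an aromatic carbon. Within the data shown here, the only measured step that touches this position is the one from compound 1 to compound 2, a 1.2-fold higher number from compound 1 to compound 2 (0.08 log units; within the scatter), and it changed nothing beyond the scatter. Among the measured compounds shown here, there is no measured step that removes the hydrogen-bond donor on this nitrogen, so the direction of any effect of that part of the change is unknown. On this basis compound 3 is expected to stay close to compound 2, with a step of a 1.1-fold higher number from compound 2 to compound 3 (0.03 log units; within the scatter) in this assay. The estimate for compound 3 is 17000 nM, with a range of 6000 nM to 48000 nM.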

Compound 3, half-maximal inhibitory concentration: > 107000 nM
Compound 3 was reported as a limit; the forecaster's own chance of this, stated with the estimate: 15%; at least 6.2-fold (0.79 log units) between middle value and limit.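

Changing ethyl to cyclopropyl on this nitrogen had moved nothing beyond the scatter, but the position is not indifferent to every change: the result is an at least 6.7-fold higher number from compound 2 to compound 3 (0.82 log units; beyond the scatter), and likewise an at least 8.0-fold higher number from compound 1 to compound 3 (0.90 log units; beyond the scatter). Compound 3 is the only compound reported as a limit, not a number, in this assay: the limit of > 107000 nM in this assay, at which 1 of the 3 values shown sits. The second step is ethyl in place of hydrogen on the nitrogen, so among these compounds a group with a hydrogen on this nitrogen stays in the same range, while diethylamino, which has no such hydrogen, gives a much weaker reading.

The compounds shown cannot separate the loss of that hydrogen from the gain of the extra ethyl. Propylamino, a longer chain that keeps the hydrogen, and dimethylamino, a smaller group without it, would help to pull these two changes apart.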